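A few compounds are considered here, and "the series" means these few. Any claim that something is new, unique, unknown or untested is made for them only; others in the source may bear on it.

Compound 3 `COC(=O)c1ccc(NCc2cncn2Cc2ccc(-c3ccccc3)cc2)cc1-c1ccccc1` stands at a limit in a toxicity assay on NIH3T3 cells (Mus musculus) for cytotoxicity, read by resazurin assay; on this read-out lower numbers stand for an effect already at smaller amounts and higher numbers for an effect only at larger amounts of compound: compound 3 gives > 1000 nM, which is a limit and not a number (the limit of > 1000 nM in this assay, at which 1 of the 3 values shown sits). Compound 1 `c1ccc(-c2ccc(Cn3cncc3CNc3cccc(-c4ccccc4)c3)cc2)cc1` gives 10000 nM. Compound 2 `CC(C)OC(=O)c1ccc(NCc2cncn2Cc2ccc(-c3ccccc3)cc2)cc1-c1ccccc1` gives > 10000 nM, again a limit (the limit of > 10000 nM in this assay, at which 1 of the 3 values shown sits). The steps a step that the limit leaves unreadable from compound 1 to compound 3, a number no lower from compound 1 to compound 2 (the limit leaves the size open) and a step that the two limits leave unreadable from compound 2 to compound 3 therefore leave their sizes unreadable because of the limit of > 1000 nM in this assay, at which 1 of the 3 values shown sits, and (the limit of > 10000 nM in this assay, at which 1 of the 3 values shown sits); none of them shows a cytotoxic effect beyond the scatter.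

Compound 4 `c1ccc(-c2ccc(Cn3cncc3CNc3ccc(-c4ccccc4)c(-c4ccccc4)c3)cc2)cc1` differs from compound 3 by phenyl in place of methoxycarbonyl on an aromatic carbon. Going by the values given here, no measured step replaces methoxycarbonyl by phenyl, so only the three values themselves bear on it, and all three sit at or past the same region. Compound 4 is expected to give 10000 nM, with a range of 3000 nM to 30000 nM. The step that the limit leaves unreadable from compound 3 to compound 4 is estimated to stay within the scatter, read against a limit.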

Compound 4, half-maximal effective concentration: > 10000 nM
Compound 4 ended at the assay's limit; the forecaster's own chance of this, stated with the estimate: 55%; the middle value sits exactly at the limit.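

In this assay compound 4 gives > 10000 nM, which is a limit of the assay. With phenyl on this aromatic carbon, ortho to a phenyl group and para to a large group, the record shows a number no lower from compound 1 to compound 4 (the limit leaves the size open), so a carbon-only aromatic ring with 0 hydrogen-bond acceptors also gives no reading of a cytotoxic effect under the limit, as the esters did. The steps to compound 4 from compound 2 and compound 3 cannot be read.

From the compounds shown here alone, whether a carboxylic acid or an amine on this carbon would give a readable number in this assay stays open.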